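The compounds below may be only part of what the source reports. "The series", "measured", "known", "first", "only" and "open" are said of these compounds alone.

Measured in a functional assay on SH-SY5Y cells (Homo sapiens) for cytotoxicity; a higher number here means a weaker inhibitor, a lower number a stronger inhibitor:
Compound 1 `CCCC(CCC)c1nc(-c2ccc(C(C)(C)C)cc2)c[nH]1` gives 430 nM
Compound 2 `CCCCCCc1nc(-c2ccc(CC(C)C)cc2)c[nH]1` gives 380 nM
Compound 3 `c1ccc(-c2ccc(-c3c[nH]c(CCC4CCCCC4)n3)cc2)cc1` gives 760 nM

These three compounds share a core but carry different groups on it. Compound 2 (380 nM) has the lowest number of the set, yet its gaps to compound 1 and compound 3 both lie within the usual scatter of repeated measurements. On these data, the three cannot be ranked.

The next compound, compound 4 `CCCCCCc1nc(-c2ccc(-c3ccccc3)cc2)c[nH]1`, keeps the hexyl chain of compound 2 and makes one change: phenyl in place of isobutyl on an aromatic carbon, (phenyl in place of isobutyl on an aromatic carbon). Going by the values given here, no two measured compounds differ in only one place, so nothing here directly measures this swap. The nearest guide is compound 3 (760 nM), which also carries phenyl in that place but has a different chain. Its value suggests that phenyl is compatible with a result in the same general range, perhaps towards the higher end.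

The expected change in this assay is small, an estimated 1.4-fold higher number from compound 2 to compound 4 (0.16 log units; within the scatter), towards a weaker result and not beyond the scatter. For compound 4 the estimated value is 550 nM, with an expected range of 230 nM to 1300 nM.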

Compound 4, half-maximal inhibitory concentration: 450 nM
For compound 4 the middle estimate is 1.2-fold (0.09 log units) above the measured one; the measured number falls inside the stated range.
By their numbers in this assay, from the lowest: compounds 2, 1, 4 and 3 (each within the scatter of the next).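

In this assay, going by these compounds alone, phenyl in place of isobutyl on an aromatic carbon, para to a large group, gives a 1.2-fold higher number from compound 2 to compound 4 (0.07 log units; within the scatter), the first direct reading at this position: an aromatic ring of carbon only can take the place of a group with no ring without moving the number beyond the scatter. With phenyl kept in that place, butyl in place of cyclohexyl on a saturated chain carbon, two bonds along the chain from an aromatic carbon, gives a 1.7-fold lower number from compound 3 to compound 4 (0.23 log units; within the scatter), so this change to the chain likewise stays within the scatter. No independent measurement is available to explain these results.

Every group shown on this aromatic carbon is built of carbon and hydrogen alone, so what an amine or a carboxylic acid would do there remains open. As far as these compounds go, it is also open whether a much longer chain on the shared core, or an amine placed on that chain, would produce a step that clears the scatter in this assay.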